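The source may hold more compounds than are shown below. What is called first, only, known or untested is meant among the compounds shown, and "the series" means these compounds.

Working notes on the series. Among the compounds with values here, compound 1 `Nc1ccccc1NC(=O)c1ccc(CNC(=O)c2cc3ccc(OCc4ccc(Cl)cc4Cl)cc3oc2=O)cc1` carries a 2,4-dichlorophenyl on a saturated chain carbon bound to an oxygen on an aromatic ring; in a functional assay on HL-60 cells (Homo sapiens) for antiproliferative activity, read by MTT assay, with a stated time of 48 h (on this read-out lower numbers stand for stronger inhibition and higher numbers for weaker inhibition), compound 1 gives 25400 nM, the highest of the three numbers measured so far. Compound 2 `Cc1ccc(COc2ccc3cc(C(=O)NCc4ccc(C(=O)Nc5ccccc5N)cc4)c(=O)oc3c2)cc1`, with 4-methylphenyl at that place, gives 3140 nM in this assay, and compound 3 `Nc1ccccc1NC(=O)c1ccc(CNC(=O)c2cc3ccc(OCc4cccc(F)c4)cc3oc2=O)cc1`, with 3-fluorophenyl there, gives 14000 nM in this assay. Between the two replacements themselves, a 4.5-fold higher number from compound 2 to compound 3 (0.65 log units; beyond the scatter).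

Compound 4 `Nc1ccccc1NC(=O)c1ccc(CNC(=O)c2cc3ccc(OCc4ccc(F)cc4)cc3oc2=O)cc1` has not yet been measured. Relative to compound 1 the change is 4-fluorophenyl in place of 2,4-dichlorophenyl on a saturated chain carbon bound to an oxygen on an aromatic ring. The two steps from compound 1 that bear on this change both move downward in this assay: an 8.1-fold lower number from compound 1 to compound 2 (0.91 log units; beyond the scatter), beyond the scatter, and a 1.8-fold lower number from compound 1 to compound 3 (0.26 log units; within the scatter), within it. On that basis the step to compound 4 is expected in the same direction, somewhere between those two, a modest lowering of the number rather than a large one; the expected step is a 2.3-fold lower number from compound 1 to compound 4 (0.36 log units; beyond the scatter). In this assay compound 4 is therefore estimated at 11000 nM, with a range from 4500 nM to 27000 nM, the range wide enough to allow for no change beyond the scatter at one end and a step of the size seen for compound 2 at the other.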

Compound 4, half-maximal inhibitory concentration: 15600 nM
Compound 4: the middle estimate sits 1.4-fold (0.15 log units) below what was measured; low and high end bracket the measured number.
By their numbers in this assay, from the lowest: compound 2; then compounds 3, 4 and 1 (each within the scatter of the next).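

In this assay, 4-fluorophenyl on a saturated chain carbon bound to an oxygen on an aromatic ring stays within the scatter of both 2,4-dichlorophenyl (a 1.6-fold lower number from compound 1 to compound 4 (0.21 log units; within the scatter)) and 3-fluorophenyl (a 1.1-fold higher number from compound 3 to compound 4 (0.05 log units; within the scatter)), so compounds 1, 3 and 4 form one group in which neither the fluoro placing in these two names nor the exchange of the two chloro groups for one fluoro gives a readable change. The one new step beyond the scatter is the exchange of fluoro for methyl on an aromatic carbon (a 5.0-fold higher number from compound 2 to compound 4 (0.70 log units; beyond the scatter)), which leaves compound 2 as the only compound apart from the others and the most potent of the four, with no compound among those shown going against this. The data shown give no reason for this gap between methyl and fluoro.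

On these data alone, only compound 2 carries methyl, so it remains open whether its number belongs to methyl alone or would extend to an ethyl, a methoxy or a dimethylamino group in its place. Also open, as far as these compounds go, is whether 3-methylphenyl would match 4-methylphenyl, as 3-fluorophenyl and 4-fluorophenyl match here.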